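Adding a hydroxy beside the bromo of compound 1

The source may report more compounds than this note shows. Statements on the series, on what has been measured and on what is new or still open speak of the compounds shown alone.

Among the measured compounds shown here, compound 1 `CN(C)CCn1cnnc1-c1cc(Oc2ccc(NC(=O)N/N=C/c3cccc(Br)c3)cc2F)ccn1` gives the lowest of the two numbers so far: in a functional assay on MKN-45 cells (Homo sapiens) for cytotoxicity, read by MTT assay, with a stated time of 72 h (on this read-out lower numbers stand for stronger inhibition and higher numbers for weaker inhibition), compound 1 gives 450 nM, while compound 2 `CN(C)CCn1cnnc1-c1cc(Oc2ccc(NC(=O)N/N=C/c3cccc(O)c3)cc2F)ccn1` gives 1370 nM, so that a 3.0-fold higher number from compound 1 to compound 2 (0.48 log units; beyond the scatter). Compound 3 `CN(C)CCn1cnnc1-c1cc(Oc2ccc(NC(=O)N/N=C/c3ccc(O)c(Br)c3)cc2F)ccn1` keeps the bromo and differs from compound 1 only by hydroxy in place of hydrogen on an aromatic carbon. For the measured compounds named here, the one step that bears on this, from compound 1 to compound 2, shows hydroxy in place of bromo weakening modestly; here hydroxy enters alongside bromo, so a smaller weakening, or none beyond the scatter, is expected: a 1.6-fold higher number from compound 1 to compound 3 (0.19 log units; within the scatter). Compound 3 is therefore estimated at 700 nM, between 300 nM and 1600 nM.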

Compound 3, half-maximal inhibitory concentration: 1860 nM
Beside the measured number, compound 3's estimate is 2.7-fold (0.42 log units) below it; the measured number lies above the stated range.
By their numbers in this assay, from the lowest: compound 1; then compounds 2 and 3 (each within the scatter of the next).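

Hydroxy on this aromatic carbon, ortho to a bromo group and para to a large group, weakens the result even with the bromo kept (a 4.1-fold higher number from compound 1 to compound 3 (0.62 log units; beyond the scatter)) in this assay. Keeping the bromo brings no gain over the 3-hydroxyphenyl compound, as the two lie within the scatter (a 1.4-fold higher number from compound 2 to compound 3 (0.13 log units; within the scatter)). No measurement given here accounts for this loss. The compounds shown leave open whether a methoxy or an amine on this carbon would behave as hydroxy does, and whether the loss depends on the bromo staying in place.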